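A few compounds are considered here, and "the series" means these few. Any claim that something is new, unique, unknown or untested is made for them only; others in the source may bear on it.

Measured in an ADME assay on a cell-free system (plasma, Homo sapiens) for metabolic stability; a lower number here means that the compound disappears faster, a higher number that the compound lasts longer:
compound 1, `Cc1cn([C@H]2C=C[C@@H](COC(=O)CNC(=O)c3ccncn3)O2)c(=O)[nH]c1=O`, 1 h
compound 2, `CCCCC(=O)OCOC(=O)Cc1c(C)n(C(=O)c2ccc(Cl)cc2)c2ccc(OC)cc12`, 2.07 h
compound 3, `CCCCN(CCCC)Cc1cccc(C(=O)OCCOCn2cnc3c(=O)[nH]c(N)nc32)c1`, 0.0383 h

Among these three numbers compound 1 stands second highest. Its nearest neighbour is compound 2, which lasts longer by an amount that lies beyond the usual scatter, while compound 3 is furthest away, disappearing far faster than compound 1. The three compounds share no common core, so the spread among them says nothing about the effect of any single change.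

Compound 4, `Cc1cn([C@H]2C=C[C@@H](COC(=O)CN(C)C)O2)c(=O)[nH]c1=O`, keeps the core of compound 1 and differs from it in one place: dimethylamino in place of ((pyrimidin-4-yl)carbonyl)amino on a saturated chain carbon bound to a carbonyl carbon. Within the data shown here, no pair of measured compounds that differ in one place is available, so the size of this step in this assay is a matter of expectation only. Compound 1 already sits at a moderate half-life, and the account expects that compound 4 will move from it by a modest amount, somewhat toward a shorter half-life, with a step from a 1.7-fold lower number from compound 1 to compound 4 (0.22 log units; within the scatter) that may well remain close to the scatter of the measurement. The half-life of compound 4 in this assay is therefore estimated at 0.6 h, with a likely range from 0.15 h to 2.5 h.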

Compound 4, half-life: 0.5 h
Beside the measured number, compound 4's estimate is 1.2-fold (0.08 log units) above it; measured number inside the range.
By their numbers in this assay, from the lowest: compound 3; then compounds 4 and 1 (each within the scatter of the next); then compound 2.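

Among these compounds, the first comparison that changes one place in the shared core comes from compound 1 and compound 4. In this assay, putting dimethylamino in place of ((pyrimidin-4-yl)carbonyl)amino on a saturated chain carbon bound to a carbonyl carbon gives a 2.0-fold lower number from compound 1 to compound 4 (0.30 log units; within the scatter), so this exchange does not separate the two compounds in half-life, even though the group that leaves has 9 heavy atoms and a six-membered aromatic ring while the group that enters has 3 heavy atoms and no ring. At this place, then, the removal of that ring and of the hydrogen-bond donor counted in the leaving group comes with no change that can be told from the scatter, although nothing shown here gives a measured reason for this result.

This single step cannot show whether other groups at this place, such as a piperidine, a carboxylic acid or a longer chain, would stay within the scatter of compound 1 or move beyond it. It also leaves open whether the same exchange would behave alike on another core, since compound 2 and compound 3 offer no one-place comparison.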